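This account rests on a few compounds, and the source may have more. Where it says the series, first, only, none or still open, it means among the compounds named here.

Compound 1 `NC(=O)[C@@H]1CC[C@H](c2ccc(OCc3ccc(F)cc3)cc2)N1`: in an ADME assay on a cell-free system (plasma, Rattus norvegicus) for protein binding (on this read-out lower numbers stand for a smaller free fraction and higher numbers for a larger free fraction), compound 1 is recorded as "not determined" (no result reported).
Compound 2 `N#Cc1ccccc1COc1ccc([C@H]2CC[C@@H](C(N)=O)N2)cc1`: compound 2 gives 0.12 in this assay.
Compound 3 `N#Cc1ccc(COc2ccc([C@H]3CC[C@@H](C(N)=O)N3)cc2)cc1`: in this assay compound 3 is recorded as "not determined" (no result reported).

For the measured compounds named here, compound 3 thus stands without a number in this assay, as does compound 1; the only value in the set belongs to compound 2, which gives 0.12 in this assay. Compound 4 `NC(=O)[C@@H]1CC[C@H](c2ccc(OCc3cccc(F)c3)cc2)N1` differs from compound 3 in one place: 3-fluorophenyl in place of 4-cyanophenyl on a saturated chain carbon bound to an oxygen on an aromatic ring. With no measured step in this assay between any pair of these compounds, the size of the move from compound 3 to compound 4 cannot be read from the data; a shift toward a smaller unbound fraction is expected, probably modest and close to the edge of the usual scatter. Compound 4 is estimated to give 0.06 in this assay, with a range from 0.025 to 0.15.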

Compound 4, unbound fraction: 0.033
Compound 4: the middle estimate sits 1.8-fold (0.26 log units) above what was measured; the range from low to high includes it.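

Moving from 2-cyanophenyl to 3-fluorophenyl on a saturated chain carbon bound to an oxygen on an aromatic ring gives a 3.6-fold lower number from compound 2 to compound 4 (0.56 log units; beyond the scatter) in this assay. This first measured comparison shows that the aromatic group at this place can shift the free fraction beyond the usual scatter. Nothing available explains the shift.

With no single number for compound 1 or compound 3, the data cannot separate the effect of exchanging nitrile for fluorine from that of its place on the ring. From the compounds shown here alone, how a phenyl group carrying a carboxylic acid or an amine would read here remains open.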